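Triazole-linked aryl sulfonamides: ring substituent swap

A few compounds are considered here, and "the series" means these few. Any claim that something is new, unique, unknown or untested is made for them only; others in the source may bear on it.

Compound 1 `Cc1ccccc1-n1cc(-c2ccccc2NS(=O)(=O)c2c[nH]c(=O)[nH]c2=O)nn1`: 6550 nM
Compound 2 `Cc1cccc(-n2cc(-c3ccccc3NS(=O)(=O)c3c[nH]c(=O)[nH]c3=O)nn2)c1`: 3150 nM

In a functional assay on OVCAR-3 cells (Homo sapiens) for antiproliferative activity, read by MTT assay, with a stated time of 24 h (a lower number here means a stronger inhibitor, a higher number a weaker inhibitor), compound 2 gives the lowest number of the two, with compound 1 next at a 2.1-fold lower number from compound 1 to compound 2 (0.32 log units; beyond the scatter). Compound 3 `O=c1[nH]cc(S(=O)(=O)Nc2ccccc2-c2cn(-c3ccccc3F)nn2)c(=O)[nH]1` differs from compound 2 by 2-fluorophenyl in place of 3-methylphenyl on an aromatic nitrogen. Among the measured compounds shown here, the only step that bears on this position is a 2.1-fold lower number from compound 1 to compound 2 (0.32 log units; beyond the scatter), where the 2-methylphenyl-bearing compound 1 gave the higher number. Compound 3 again carries its substituent at the 2-position, so a modest rise is expected, a 1.4-fold higher number from compound 2 to compound 3 (0.15 log units; within the scatter). Compound 3 is estimated at 4500 nM, range 2000 nM to 10000 nM.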

Compound 3, half-maximal inhibitory concentration: 15300 nM
Estimate against measurement, compound 3: 3.4-fold (0.53 log units) below; measured number outside the range, above it.
By their numbers in this assay, from the lowest: compound 2; then compound 1; then compound 3.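

In this assay the change from 3-methylphenyl to 2-fluorophenyl gives a 4.9-fold higher number from compound 2 to compound 3 (0.69 log units; beyond the scatter) and puts compound 3 at the top of the three numbers. The change from 2-methylphenyl to 2-fluorophenyl gives a 2.3-fold higher number from compound 1 to compound 3 (0.37 log units; beyond the scatter) as well, so the identity of the group matters here, not only its place on the phenyl ring. No evidence at hand accounts for either step.

Compound 2 and compound 3 differ in both group and ring place, and a 3-fluorophenyl compound would separate the two. As far as these compounds go, whether a chloro, methoxy or amino group on this phenyl ring follows the same order remains open.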